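This account rests on a few compounds, and the source may have more. Where it says the series, first, only, none or still open, it means among the compounds named here.

Of the compounds shown here, three have so far been measured in an assay on membranes from brain for displacement of a labelled ligand from Neuronal acetylcholine receptor; alpha4/beta2 (Rattus norvegicus); a lower number here means a stronger inhibitor, a higher number a weaker inhibitor. Compound 1 `CSc1ncccc1OC[C@@H]1CCCN1C` gives 559 nM, compound 3 `CN1CCC[C@H]1COc1cc(Br)c[n+]([O-])c1` gives 34.8 nM, and compound 2 `CCc1cncc(OC[C@@H]2CCCN2C)c1` gives 0.32 nM, the lowest of the three numbers; its gap to compound 3 and its gap to compound 1 both lie beyond the usual scatter. Compound 4 `CN1CCC[C@H]1COc1cncc([N+](=O)[O-])c1` has not yet been measured in this assay. It differs from compound 2 by one change, (nitro in place of ethyl on an aromatic carbon), that is, nitro in place of ethyl on an aromatic carbon. Within the data shown here, no measured pair shows this change, so the size of the step is uncertain. Compound 4 is expected to be somewhat weaker, with an estimated step of a 4.7-fold higher number from compound 2 to compound 4 (0.67 log units; beyond the scatter). The estimate for compound 4 is 1.5 nM, expected to fall between 0.3 nM and 8 nM.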

Compound 4, inhibition constant: 4.65 nM
Compound 4: middle estimate off by 3.1-fold (0.49 log units), on the low side; low and high end bracket the measured number.
By their numbers in this assay, from the lowest: compound 2; then compound 4; then compound 3; then compound 1.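

In this assay, among these compounds, placing nitro instead of ethyl on this aromatic carbon, two atoms from the ring nitrogen, gives a 15-fold higher number from compound 2 to compound 4 (1.16 log units; beyond the scatter) and is the first direct reading of a change at this position, showing that the number depends strongly on the group held there. Even so, compound 4 stays in the low range at 4.65 nM for this series, so ethyl is not the only group compatible with a low number. The data offer no explanation for the size of this step.

Only these two groups can be compared directly at this carbon. Going by these compounds, how an amine, a carboxylic acid or a longer chain would fare there remains open.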